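Swapping the Phenoxy Group: Expected Cytotoxicity of Compound 4

The source may report more compounds than this note shows. Statements on the series, on what has been measured and on what is new or still open speak of the compounds shown alone.

Of the compounds shown here, three sharing one core have been read in an ADME assay on MT4 cells (Homo sapiens) for cytotoxicity, read by MTT assay, with a stated time of 4 days; a lower number here means that less compound is tolerated, a higher number that more compound is tolerated. Compound 1 `N#Cc1ccc(Nc2nc(Oc3ccccc3Cl)c3ccccc3n2)cc1` gives 38000 nM in this assay , the highest of the three numbers. Compound 3 `CCOc1cc(C#N)cc(Cl)c1Oc1nc(Nc2ccc(C#N)cc2)nc2ccccc12` gives 22000 nM, and the gap between compound 1 and compound 3 stays within the scatter, so the two cannot be put in order. Compound 2 `CCCOc1cc(C#N)cc(OC)c1Oc1nc(Nc2ccc(C#N)cc2)nc2ccccc12` gives 5200 nM, and here the gap to compound 1 lies beyond the scatter, so compound 2 is the one of the three for which less compound is tolerated. Among the measured compounds shown here, no two of the measured compounds differ in a single place, so no measured step is available to lean on.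

Compound 4 `Cc1ccc(Oc2nc(Nc3ccc(C#N)cc3)nc3ccccc23)cc1` has not yet been measured in this assay . It differs from compound 1 in one place: 4-methylphenyl in place of 2-chlorophenyl on an oxygen on an aromatic ring. The group that leaves and the group that enters are alike in size, in ring count and in the absence of donors and acceptors. With nothing in the measured compounds pointing one way, the step from compound 1 to compound 4 is expected to be small and to stay within the scatter, a 1.3-fold lower number from compound 1 to compound 4 (0.10 log units; within the scatter). Compound 4 is therefore estimated at 30000 nM in this assay , with a plausible range from 10000 nM to 80000 nM.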

Compound 4, half-maximal cytotoxic concentration: 87000 nM
Compound 4: the middle estimate sits 2.9-fold (0.46 log units) below what was measured; measured number above the stated range.
By their numbers in this assay, from the lowest: compound 2; then compounds 3 and 1 (each within the scatter of the next); then compound 4.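

The phenoxy position on the shared core is not a neutral place in this assay: 4-methylphenyl in place of 2-chlorophenyl on an oxygen on an aromatic ring gives a 2.3-fold higher number from compound 1 to compound 4 (0.36 log units; beyond the scatter), even though the two groups are alike in heavy-atom count, in ring count and in the absence of donors and acceptors. This is the first single-place step among the compounds shown, and it establishes that a swap between groups matched in these counted features can still carry the number beyond the scatter, though only modestly. No evidence bearing on the origin of this step is at hand.

The step changes the substituent and its place on the ring together, so the compounds shown cannot say whether the result follows from losing the chlorine, gaining the methyl or moving the substituent; 4-chlorophenyl and 2-methylphenyl would separate these readings. As far as these compounds go, it also remains open whether the same step would hold with a phenoxy group carrying an amine or a carboxylic acid, or on the more heavily substituted rings of compound 2 and compound 3.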